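Swapping the Amine Tail of Compound 3

The source may report more compounds than this note shows. Statements on the series, on what has been measured and on what is new or still open speak of the compounds shown alone.

Four compounds share a core with one carbonyl-bearing side chain. In a functional assay on HepG2 cells (Homo sapiens) for cytotoxicity, read by MTT assay, with a stated time of 48 h (on this read-out higher numbers stand for weaker inhibition and lower numbers for stronger inhibition), compound 1 `CC1=NN(C(=O)/C=C/c2ccccc2)C(c2ccccc2O)C1` gives 29000 nM. Compound 2 `CC1=NN(C(=O)COc2ccc(Cl)cc2)C(c2ccccc2O)C1` gave "not active" (no number reported) in this assay, with no number reported. Compound 3 `CCCNCC(=O)N1N=C(c2cc3ccccc3oc2=O)CC1c1ccccc1` gives 10800 nM, the lowest of the two numbers, and its gap to compound 1 lies beyond the scatter. Compound 4 `O=C(CN1CCC(O)CC1)N1N=C(c2cc3ccccc3oc2=O)CC1c1ccccc1` has not yet been measured. Compound 4 differs from compound 3 in one place: 4-hydroxypiperidin-1-yl in place of propylamino on a saturated chain carbon bound to a carbonyl carbon. Within the data shown here, no measured pair tells how such a swap shifts cytotoxicity, so the step from compound 3 to compound 4 is expected to stay small, a 1.1-fold higher number from compound 3 to compound 4 (0.05 log units; within the scatter), in no settled direction. Compound 4 is estimated at 12000 nM, between 4000 nM and 40000 nM.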

Compound 4, half-maximal inhibitory concentration: "not active" (no number reported)
For compound 4 the study gives words and no number; there is nothing to compare the estimate with.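

Among these compounds, compound 4 is reported as "not active" without a number, so no step from compound 3 to compound 4 can be read. The compounds shown leave open how far 4-hydroxypiperidin-1-yl in place of propylamino shifts cytotoxicity. Nothing available explains this result.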